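Branching the chain next to the ring nitrogen

The source may report more compounds than this note shows. Statements on the series, on what has been measured and on what is new or still open speak of the compounds shown alone.

Measured compounds:
compound 1, `Cc1cc(-c2ccccc2)nnc1NCCCN`, in a functional assay on the whole organism with Mus musculus as the target (a higher number here means that more compound is needed for the effect, a lower number that less compound is needed), gives 0.1 mg/kg
compound 3, `Cc1cc(-c2ccccc2)nnc1NCCN`, gives 0.5 mg/kg
compound 2, `CCN(CC)CCNc1nnc(-c2ccccc2)cc1C`, reaches only a limit of this assay, > 10 mg/kg

Compound 3 stands highest of the two numbers; the nearest is compound 1, as the step of a 5.0-fold higher number from compound 1 to compound 3 (0.70 log units; beyond the scatter) shows. Compound 4, `Cc1cc(-c2ccccc2)nnc1NC(C)CN`, differs from compound 3 by methyl in place of hydrogen on a saturated chain carbon bound to a nitrogen on an aromatic ring and a saturated chain carbon. Going by the values given here, no measured step touches this carbon: an at least 100-fold higher number from compound 1 to compound 2 (2.00 log units; beyond the scatter) and an at least 20-fold lower number from compound 2 to compound 3 (1.30 log units; beyond the scatter) concern the terminal amine, and a 5.0-fold higher number from compound 1 to compound 3 (0.70 log units; beyond the scatter) the chain length. The step in this assay from compound 3 is therefore expected to be small, a 1.2-fold higher number from compound 3 to compound 4 (0.08 log units; within the scatter), and compound 4 is estimated at 0.6 mg/kg, likely between 0.15 mg/kg and 2.5 mg/kg.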

Compound 4, minimum effective dose: 2 mg/kg
The estimate for compound 4 lay 3.3-fold (0.52 log units) below the measured number; measured number inside the range.
By their numbers in this assay, from the lowest: compound 1; then compound 3; then compound 4. At a limit, above all of these: compound 2.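

Going by these compounds alone, on the saturated chain carbon bound to the nitrogen on the aromatic ring, a single methyl in place of hydrogen raises the dose needed in this assay (a 4.0-fold higher number from compound 3 to compound 4 (0.60 log units; beyond the scatter)), so this carbon, untouched by the earlier steps, does matter. The branched 1-(aminomethyl)ethyl chain also falls well behind the 3-aminopropyl chain (a 20-fold higher number from compound 1 to compound 4 (1.30 log units; beyond the scatter)). Against the 2-(diethylamino)ethyl chain, whose value is a limit, the difference is only a bound (an at least 5.0-fold lower number from compound 2 to compound 4 (0.69 log units; beyond the scatter)).

On these data alone, whether an ethyl group on this carbon would raise the number further remains open, as does whether methyl would act the same way on the 3-aminopropyl chain.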